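From but-3-en-1-yl to 2-methoxyethyl on compound 2

A few compounds are considered here, and "the series" means these few. Any claim that something is new, unique, unknown or untested is made for them only; others in the source may bear on it.

Measured in a functional assay on MCF7 cells (Homo sapiens) for antiproliferative activity; on this read-out lower numbers stand for stronger inhibition and higher numbers for weaker inhibition:
Compound 1 `O=C(CCCCCCC(=O)Nc1ccc(Nc2nc(-c3cn[nH]c3)c3cc[nH]c3n2)cc1)NO`: 15600 nM
Compound 2 `C=CCCn1cc(-c2nc(Nc3ccc(NC(=O)CCCCCCC(=O)NO)cc3)nc3[nH]ccc23)cn1`: 4500 nM

Compound 2 holds the lower of the two numbers. Compound 3 `COCCn1cc(-c2nc(Nc3ccc(NC(=O)CCCCCCC(=O)NO)cc3)nc3[nH]ccc23)cn1` differs from it by one change, (methoxy in place of vinyl on a saturated chain carbon, two bonds along the chain from an aromatic nitrogen), methoxy in place of vinyl on a saturated chain carbon, two bonds along the chain from an aromatic nitrogen. Among the compounds with values here, one measured step bears on this: a 3.5-fold lower number from compound 1 to compound 2 (0.54 log units; beyond the scatter), with but-3-en-1-yl in place of hydrogen on an aromatic nitrogen. Given that modest step, and with a chain kept in compound 3, only a small move toward a higher number is expected in this assay, likely within the scatter. The expected step is a 1.2-fold higher number from compound 2 to compound 3 (0.09 log units; within the scatter). Compound 3 is estimated at 5500 nM, with a range of 2300 nM to 13000 nM.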

Compound 3, half-maximal inhibitory concentration: 12200 nM
Estimate against measurement, compound 3: 2.2-fold (0.35 log units) below; the range from low to high includes it.
By their numbers in this assay, from the lowest: compound 2; then compounds 3 and 1 (each within the scatter of the next).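

At this saturated chain carbon, two bonds along the chain from an aromatic nitrogen, the swap of vinyl for methoxy in this assay moved the number beyond the scatter (a 2.7-fold higher number from compound 2 to compound 3 (0.43 log units; beyond the scatter)), so the gain seen with but-3-en-1-yl did not hold for every chain on that nitrogen. The 2-methoxyethyl chain left the number within the scatter of the unsubstituted nitrogen (a 1.3-fold lower number from compound 1 to compound 3 (0.11 log units; within the scatter)). Nothing measured here explains this difference. Going by these compounds, whether an amine or a carboxylic acid at this place, or a longer chain, would behave like vinyl or like methoxy remains open.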